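Replacing 4-aminocyclohexyl with 2-aminoethyl on the shared core

The compounds below may be only part of what the source reports. "The series", "measured", "known", "first", "only" and "open" are said of these compounds alone.

For the measured compounds named here, compound 3 (`N[C@H]1CC[C@H](Nc2c(C(=O)NCc3ccc(F)cc3)nc(Br)c3cccnc23)CC1`) gives 4000 nM in a functional assay on HCT-116 cells (Homo sapiens) for cytotoxicity, read by MTT assay, with a stated time of 72 h (a lower number here means a stronger inhibitor, a higher number a weaker inhibitor), and holds the lowest of the two numbers so far. Compound 1 (`NCCCNc1c(C(=O)NCc2ccc(F)cc2)nc(Br)c2cccnc12`) stands at 18000 nM in this assay and carries 3-aminopropyl on the same nitrogen. Exchanging that chain for 4-aminocyclohexyl is a 4.5-fold lower number from compound 1 to compound 3 (0.65 log units; beyond the scatter) and is the closest measured guide. Compound 2 (`CN(C)CCCNc1c(C(=O)NCc2ccc(F)cc2)nc(Br)c2cccnc12`) is reported only as a limit of the assay at > 10000 nM and not as a number. Against that limit, the exchange for 4-aminocyclohexyl shows an at least 2.5-fold lower number from compound 2 to compound 3 (0.39 log units; beyond the scatter) in this assay.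

Compound 4 (`NCCNc1c(C(=O)NCc2ccc(F)cc2)nc(Br)c2cccnc12`) has 2-aminoethyl in place of 4-aminocyclohexyl on a nitrogen on an aromatic ring. Its open chain is closest to that of compound 1, so a higher number of similar size is expected, reversing a 4.5-fold lower number from compound 1 to compound 3 (0.65 log units; beyond the scatter) in this assay. The estimated change is a 4.0-fold higher number from compound 3 to compound 4 (0.60 log units; beyond the scatter) in this assay. The estimated value for compound 4 is 16000 nM with an expected range of 6000 nM to 40000 nM in this assay.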

Compound 4, half-maximal inhibitory concentration: > 20000 nM
Compound 4: only a limit was reported; the forecaster's own chance of this, stated with the estimate: 35%; middle value at least 1.2-fold (0.09 log units) away from the limit.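

Compound 4 is reported only as a limit of the assay and not as a number: the limit of > 20000 nM in this assay, at which 1 of the 4 values shown sits. In this assay, exchanging 4-aminocyclohexyl for 2-aminoethyl gives an at least 5.0-fold higher number from compound 3 to compound 4 (0.69 log units; beyond the scatter), so a second open chain on this nitrogen also stays well short of the ring-bearing group. Against 3-aminopropyl, 2-aminoethyl gives an at least 1.1-fold higher number from compound 1 to compound 4 (0.04 log units; that floor lies within the scatter), a floor that allows no order between the two chains, and the step between the two limits, from compound 2 to compound 4, cannot be read.

The compounds shown leave open whether the lower number of compound 3 belongs to the cyclohexyl ring or to the amino group it carries. Plain cyclohexyl or 4-hydroxycyclohexyl on the same nitrogen would separate the two, and a longer chain such as 5-aminopentyl would test chain length.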